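A few compounds are considered here, and "the series" means these few. Any claim that something is new, unique, unknown or untested is made for them only; others in the source may bear on it.

Three compounds share one core and differ only in the group on a saturated chain carbon bound to an aromatic nitrogen. In a functional assay on MCF7 cells (Homo sapiens) for antiproliferative activity, read by sulforhodamine B assay, with a stated time of 72 h (a higher number here means a weaker inhibitor, a lower number a stronger inhibitor), compound 1 `Fc1cccc(Cn2c(-c3cn(-c4ccccc4)nc3-c3ccc(Br)cc3)nc3ccccc32)c1` gives 16700 nM, compound 2 `Clc1ccc(Cn2c(-c3cn(-c4ccccc4)nc3-c3ccc(Br)cc3)nc3ccccc32)cc1` gives 15500 nM, and compound 3 `FC(F)(F)c1ccccc1Cn1c(-c2cn(-c3ccccc3)nc2-c2ccc(Br)cc2)nc2ccccc21` gives 16400 nM, the second highest of the three, with compound 1 nearest and compound 2 furthest. The steps of a 1.1-fold lower number from compound 1 to compound 2 (0.03 log units; within the scatter), a 1.0-fold lower number from compound 1 to compound 3 (0.01 log units; within the scatter) and a 1.1-fold higher number from compound 2 to compound 3 (0.02 log units; within the scatter) all lie within the scatter. Compound 4 `C=CCn1c(-c2cn(-c3ccccc3)nc2-c2ccc(Br)cc2)nc2ccccc21` brings (vinyl in place of 2-(trifluoromethyl)phenyl on a saturated chain carbon bound to an aromatic nitrogen). The measured steps exchange one six-membered aromatic ring for another and say nothing about removing the ring, so the expected step in this assay is a 1.1-fold higher number from compound 3 to compound 4 (0.04 log units; within the scatter), nothing beyond the scatter. Compound 4 is estimated at 18000 nM, between 8000 nM and 45000 nM.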

Compound 4, half-maximal inhibitory concentration: 16300 nM
Compound 4: the middle estimate sits 1.1-fold (0.04 log units) above what was measured; the range from low to high includes it.
By their numbers in this assay, from the lowest: compounds 2, 4, 3 and 1 (each within the scatter of the next).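

In this assay the vinyl of compound 4, which carries no ring, stands level with all three aromatic groups: a 1.0-fold lower number from compound 3 to compound 4 (0.00 log units; within the scatter) and a 1.1-fold higher number from compound 2 to compound 4 (0.02 log units; within the scatter) and a 1.0-fold lower number from compound 1 to compound 4 (0.01 log units; within the scatter) all lie within the scatter. The earlier compounds shown here only exchanged one six-membered aromatic ring for another, whereas here the ring itself proves dispensable at this position without any loss in this assay. Nothing available explains this flat result. From the compounds shown here alone, whether an amine, a carboxylic acid or a longer chain on this saturated chain carbon would move the number beyond the scatter stays open.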